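From methoxycarbonyl to methylsulfonyl on a shared core

The compounds below may be only part of what the source reports. "The series", "measured", "known", "first", "only" and "open" are said of these compounds alone.

In a functional assay for inhibition, with Homo sapiens as the target (a higher number here means a weaker inhibitor, a lower number a stronger inhibitor), compound 3 `COC(=O)C(Cc1cccc(OCC(=O)O)c1)c1nc(-c2ccccc2)c(-c2ccccc2)o1` gives 80 nM. Compound 2 `CCOC(=O)/C(=C\c1cccc(OCC(=O)O)c1OC)c1nc(-c2ccccc2)c(-c2ccccc2)o1` gives 130 nM, and these two numbers lie within the scatter of each other, so neither counts as the better inhibitor. Compound 1 `CCOC(=O)/C(=C\c1cccc(OCC(=O)OC(C)(C)C)c1)c1nc(-c2ccccc2)c(-c2ccccc2)o1` reads > 60000 nM, which is a limit of the assay and not a number. Compound 4 `CS(=O)(=O)C(Cc1cccc(OCC(=O)O)c1)c1nc(-c2ccccc2)c(-c2ccccc2)o1` keeps the frame of compound 3 but carries methylsulfonyl in place of methoxycarbonyl on a saturated chain carbon bound to an aromatic carbon and a saturated chain carbon. Within the data shown here, no measured pair isolates this swap, so any forecast is loose. The expected step is a 1.9-fold higher number from compound 3 to compound 4 (0.27 log units; within the scatter), which would stay within the scatter. For compound 4 the estimated value in this assay is 150 nM, with a range from 40 nM to 600 nM.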

Compound 4, half-maximal inhibitory concentration: 7960 nM
The estimate for compound 4 lay 53-fold (1.72 log units) below the measured number; measured number outside the range, above it.
By their numbers in this assay, from the lowest: compounds 3 and 2 (each within the scatter of the next); then compound 4. At a limit, above all of these: compound 1.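

In this assay, the saturated chain carbon bound to an aromatic carbon and a saturated chain carbon proves sensitive to what it carries: methylsulfonyl in place of methoxycarbonyl gives a 100-fold higher number from compound 3 to compound 4 (2.00 log units; beyond the scatter) on an otherwise unchanged compound. The two groups match in heavy atoms and in hydrogen-bond acceptors, so those counts alone do not set the outcome at this place. Nothing measured here accounts for the size of this step. Going by these compounds, whether a nitrile, an amide or a carboxylic acid at this place would keep the number near that of compound 3 stays open. So does whether the same swap would have a similar effect on the core of compound 2.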